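From 4-chlorophenyl to 3-chlorophenyl in the series

The source may report more compounds than this note shows. Statements on the series, on what has been measured and on what is new or still open speak of the compounds shown alone.

In a physicochemical assay for solubility, at pH 7.4 (on this read-out higher numbers stand for higher solubility and lower numbers for lower solubility), compound 3 `Cc1cc(NC(=O)Nc2ccc(Cl)cc2)c2ccccc2n1` gives 1400 nM, the second highest of three numbers. Compound 2 `Cc1cc(NC(=O)Nc2ccccc2F)c2ccccc2n1` stands higher at 3800 nM and compound 1 `COC(=O)c1cccc(NC(=O)Nc2cc(C)nc3ccccc23)c1` lower at 600 nM, and both gaps lie beyond the usual scatter.

The next compound is compound 4 `Cc1cc(NC(=O)Nc2cccc(Cl)c2)c2ccccc2n1`, which has the same atoms as compound 3, joined differently: 3-chlorophenyl in place of 4-chlorophenyl on an amide-type nitrogen whose other neighbour is the carbonyl carbon (3-chlorophenyl in place of 4-chlorophenyl on an amide-type nitrogen).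

Within the data shown here, only one measured step bears on this change: a 2.7-fold lower number from compound 2 to compound 3 (0.43 log units; beyond the scatter), a modest step with 4-chlorophenyl in place of 2-fluorophenyl on the same kind of nitrogen. That step exchanged fluorine for chlorine as well, so it serves as a rough guide to size and not to direction. Among the measured compounds shown here, compound 1 is joined to compound 3 by no single-place step. For the measured compounds named here, no measured pair isolates a move of the chlorine alone, so no step beyond the scatter is expected in this assay, in either direction. The anchor is therefore compound 3 at 1400 nM. The expected change is a 1.1-fold higher number from compound 3 to compound 4 (0.03 log units; within the scatter). The estimate for compound 4 is 1500 nM, with an expected range of 650 nM to 3200 nM.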

Compound 4, solubility: 800 nM
For compound 4 the middle estimate is 1.9-fold (0.27 log units) above the measured one; the range from low to high includes it.
By their numbers in this assay, from the lowest: compounds 1, 4 and 3 (each within the scatter of the next, the first and the last beyond it); then compound 2.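

Among these compounds, compound 3 and compound 4 form the first pair that isolates the place of the chlorine on the ring carried by the amide-type nitrogen, and the result is a 1.8-fold lower number from compound 3 to compound 4 (0.24 log units; within the scatter); in this assay, 3-chlorophenyl and 4-chlorophenyl are therefore not told apart. Compound 2 remains separate from both chlorophenyl compounds, with a 2.7-fold lower number from compound 2 to compound 3 (0.43 log units; beyond the scatter) and now a 4.8-fold lower number from compound 2 to compound 4 (0.68 log units; beyond the scatter), both printed as beyond the scatter. Chloro in place of methoxycarbonyl on an aromatic carbon gives a 1.3-fold higher number from compound 1 to compound 4 (0.12 log units; within the scatter), so this exchange on the ring also shows no difference beyond the scatter.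

No available evidence accounts for any of these numbers.

Each step from 2-fluorophenyl changes the halogen and its place together, so the compounds shown do not separate those two changes. Among the compounds shown here, also open is what an amine or a carboxylic acid in place of the chlorine on this ring would give in this assay, since chloro and methoxycarbonyl are the only groups compared there on the shared core.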